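A few compounds are considered here, and "the series" means these few. Any claim that something is new, unique, unknown or untested is made for them only; others in the source may bear on it.

Measured so far:
- compound 1 `Cc1ccccc1CNc1nn(-c2ccc(F)cc2F)cc1CNCCN1CCN(C)CC1`: > 20000 nM
- compound 2 `CN1CCN(CCNCc2cn(-c3ccc(F)cc3F)nc2Cc2ccccc2)CC1`: > 20000 nM
- compound 3 `Cc1cccc(-c2nn(-c3ccc(F)cc3F)cc2CNCCN2CCN(C)CC2)c1`: > 20000 nM

In an ADME assay on Huh-7 cells (Homo sapiens) for cytotoxicity (a lower number here means that less compound is tolerated, a higher number that more compound is tolerated), compound 3 gives > 20000 nM, which is a limit of the assay and not a number. Compound 1 likewise sits at a limit, > 20000 nM. Compound 2 also sits at a limit, > 20000 nM. The three steps that connect them, a step that the two limits leave unreadable from compound 1 to compound 2, a step that the two limits leave unreadable from compound 1 to compound 3 and a step that the two limits leave unreadable from compound 2 to compound 3, therefore carry no readable size; all that is known is the limit of > 20000 nM in this assay, at which 3 of the 3 values shown sit.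

Compound 4 `CN1CCN(CCNCc2cn(-c3ccc(F)cc3F)nc2-c2ccc(S(=O)(=O)N(C)C)cc2)CC1` differs from compound 3 by 4-(dimethylsulfamoyl)phenyl in place of 3-methylphenyl on an aromatic carbon. Among the compounds with values here, the steps that bear on this position give no measurable change, so the expectation for compound 4 is that it again reaches the limit. Compound 4 is estimated at 25000 nM, between 10000 nM and 60000 nM. The expected step is a step that the limit leaves unreadable from compound 3 to compound 4.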

Compound 4, half-maximal cytotoxic concentration: > 20000 nM
Compound 4: no number, only a limit (the forecaster's own chance of this, stated with the estimate: 80%); the middle value lies beyond the limit too.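

In this assay compound 4 gives > 20000 nM, a limit and not a number. No step from compound 1, compound 2 or compound 3 to compound 4 can be read: the limit of > 20000 nM in this assay, at which 4 of the 4 values shown sit.

The compounds shown leave open whether any of these groups on the aromatic carbon changes the tolerated concentration in this assay.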